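Solubility of three amides and an expected thiazole analogue

This account rests on a few compounds, and the source may have more. Where it says the series, first, only, none or still open, it means among the compounds named here.

Compound 1 `COc1ccc(NC(=O)COc2cc(C)nc3ccc(OC)cc23)cc1`: in a physicochemical assay for solubility, in phosphate buffer, measured as kinetic solubility, with a stated time of 1 h, at pH 7.4 (on this read-out lower numbers stand for lower solubility and higher numbers for higher solubility), compound 1 gives 108000 nM.
Compound 2 `COc1ccc2nc(C)cc(OCC(=O)Nc3ccc(Br)c(C)c3)c2c1`: in this assay compound 2 gives < 1000 nM, which is a limit of the assay and not a number.
Compound 3 `COc1ccc2nc(C)cc(OCC(=O)Nc3ccc(F)cc3)c2c1`: in this assay compound 3 gives 104000 nM.

Of the two numbers shown, compound 3 and compound 1 sit together, since the step of a 1.0-fold lower number from compound 1 to compound 3 (0.02 log units; within the scatter) lies within the scatter. Compound 2 stands apart at the limit of < 1000 nM in this assay, at which 1 of the 3 values shown sits.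

Compound 4 `COc1ccc2nc(C)cc(OCC(=O)Nc3nc(C)c(C)s3)c2c1` differs from compound 3 in one place: 4,5-dimethyl-1,3-thiazol-2-yl in place of 4-fluorophenyl on an amide-type nitrogen. Among the measured compounds shown here, two measured steps touch the group on the amide-type nitrogen, and both were large: an at least 100-fold lower number from compound 1 to compound 2 (2.03 log units; beyond the scatter) and an at least 100-fold higher number from compound 2 to compound 3 (2.01 log units; beyond the scatter). The small exchange in a 1.0-fold lower number from compound 1 to compound 3 (0.02 log units; within the scatter), by contrast, left the number unchanged. For the measured compounds named here, neither bromo-methyl nor methoxy groups enter here, so no measured step matches the thiazole change directly. Compound 4 is therefore expected to fall somewhat, as a 3.5-fold lower number from compound 3 to compound 4 (0.54 log units; beyond the scatter). The estimate for compound 4 in this assay is 30000 nM, with a range from 3000 nM to 150000 nM.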

Compound 4, solubility: 31500 nM
The estimate for compound 4 lay 1.1-fold (0.02 log units) below the measured number; low and high end bracket the measured number.
By their numbers in this assay, from the lowest: compound 4; then compounds 3 and 1 (each within the scatter of the next). At a limit, below all of these: compound 2.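

In this assay, among the compounds shown here, the 4,5-dimethyl-1,3-thiazol-2-yl group gives the first intermediate change on the amide-type nitrogen: a 3.3-fold lower number from compound 3 to compound 4 (0.52 log units; beyond the scatter) and a 3.4-fold lower number from compound 1 to compound 4 (0.54 log units; beyond the scatter), both modest, whereas the earlier steps at this place were either within the scatter or large. A ring that is not a phenyl ring is thus tolerated at this place with a measurable loss, and the number stays far from the bottom of the series, with an at least 31-fold higher number from compound 2 to compound 4 (1.49 log units; beyond the scatter). The value of compound 2 is a limit of the assay and not a number: the limit of < 1000 nM in this assay, at which 1 of the 4 values shown sits.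

From the compounds shown here alone, whether the step belongs to the thiazole ring itself or to its methyl groups stays open. Also open, going by these compounds, is how a pyridine ring at this place, or an amine or a carboxylic acid on the ring, would read in this assay.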